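The source may hold more compounds than are shown below. What is called first, only, known or untested is meant among the compounds shown, and "the series" means these compounds.

Values in an ADME assay on BJ cells (Homo sapiens), read by MTT assay, with a stated time of 3 days; on this read-out higher numbers stand for weaker inhibition and lower numbers for stronger inhibition:
- compound 1 `CN(C)c1ncnc2[nH]cc(Sc3cccs3)c12`: 145000 nM
- compound 2 `CNc1ncnc2[nH]cc(Sc3cccs3)c12`: 132000 nM
- compound 3 `Nc1ncnc2[nH]cc(Sc3cccs3)c12`: > 150000 nM

The entry for compound 3, > 150000 nM, is a limit and not a number. The steps around it show no separation among the three compounds: a 1.1-fold lower number from compound 1 to compound 2 (0.04 log units; within the scatter), an at least 1.0-fold higher number from compound 1 to compound 3 (0.01 log units; that floor lies within the scatter), and an at least 1.1-fold higher number from compound 2 to compound 3 (0.05 log units; that floor lies within the scatter). All three steps alter only the groups on the amino nitrogen, so they bear weakly on compound 4 `c1csc(Sc2c[nH]c3ncnc(-c4cccs4)c23)c1`. There, the change is larger: thiophen-2-yl in place of amino on an aromatic carbon. A modest move to a lower number in this assay is expected, possibly within the scatter. The expected change is an at least 1.5-fold lower number from compound 3 to compound 4 (0.17 log units; that floor lies within the scatter). Compound 4 is estimated at 100000 nM, with an expected range of 45000 nM to 170000 nM.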

Compound 4, half-maximal inhibitory concentration: 23400 nM
Compound 4: middle estimate off by 4.3-fold (0.63 log units), on the high side, and the stated range ends above it.
By their numbers in this assay, from the lowest: compound 4; then compounds 2 and 1 (each within the scatter of the next). At a limit, above all of these: compound 3.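

In this assay, thiophen-2-yl at this aromatic carbon moves the number well beyond the scatter, which no change on the amino nitrogen did: a 5.6-fold lower number from compound 2 to compound 4 (0.75 log units; beyond the scatter) and a 6.2-fold lower number from compound 1 to compound 4 (0.79 log units; beyond the scatter). Against compound 3 the same change reads only as a floor, an at least 6.4-fold lower number from compound 3 to compound 4 (0.80 log units; beyond the scatter). Compound 3 stands at a limit and not a number: the limit of > 150000 nM in this assay, at which 1 of the 4 values shown sits.

Whether this shift needs an aromatic ring at this carbon remains open, since a phenyl ring and a plain alkyl chain are not among the compounds shown. Also open, on these data alone, is whether the thiophen-2-yl sulfur matters, which a furan-2-yl group would address.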